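Swapping a Methyl for Pyridin-4-yl on a Carbonyl Carbon

The compounds below may be only part of what the source reports. "The series", "measured", "known", "first", "only" and "open" are said of these compounds alone.

Of the compounds shown here, three sharing one large core have been tested in a functional assay on MCF7 cells (Homo sapiens) for antiproliferative activity, read by MTT assay, with a stated time of 48 h; on this read-out lower numbers stand for stronger inhibition and higher numbers for weaker inhibition. Going by the values given here, compound 3 `C=C1[C@H](OC(C)=O)[C@@H](OC(C)=O)[C@@H](OC(C)=O)C(C)(C)/C=C/[C@H](C)[C@H](OC(=O)c2ccccc2)[C@@]2(O)C[C@@](C)(OC(C)=O)[C@H](OC(C)=O)[C@@H]2[C@H]1OCC(C)C` is the only one with a definite number: in this assay compound 3 gives 74300 nM. Compound 1 `C=C1[C@H](OC(C)=O)[C@@H](OC(C)=O)[C@@H](OC(C)=O)C(C)(C)/C=C/[C@H](C)[C@H](OC(=O)c2ccccc2)[C@@]2(O)C[C@@](C)(O)[C@H](OC(C)=O)[C@@H]2[C@H]1OCC(C)C` reaches only the limit of the assay, giving > 100000 nM. Compound 2 `C=C1[C@H](OC(C)=O)[C@@H](OC(=O)c2cccc(C)c2)[C@@H](OC(C)=O)C(C)(C)/C=C/[C@H](C)[C@H](OC(=O)c2ccccc2)[C@@]2(O)C[C@@](C)(OC(C)=O)[C@H](OC(C)=O)[C@@H]2[C@H]1OCC(C)C` likewise gives only a limit, > 100000 nM. One step, an acetyl in place of hydrogen on an oxygen on a saturated carbon, shows an at least 1.3-fold lower number from compound 1 to compound 3 (0.12 log units; that floor lies within the scatter); the other, a methyl in place of 3-methylphenyl on a carbonyl carbon, shows an at least 1.3-fold lower number from compound 2 to compound 3 (0.12 log units; that floor lies within the scatter). Both rest on (the limit of > 100000 nM in this assay, at which 2 of the 3 values shown sit), so neither gives a firm size.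

Compound 4 `C=C1[C@H](OC(C)=O)[C@@H](OC(C)=O)[C@@H](OC(C)=O)C(C)(C)/C=C/[C@H](C)[C@H](OC(=O)c2ccccc2)[C@@]2(O)C[C@@](C)(OC(=O)c3ccncc3)[C@H](OC(C)=O)[C@@H]2[C@H]1OCC(C)C` differs from compound 3 by pyridin-4-yl in place of methyl on a carbonyl carbon. This is the same kind of position that the step from compound 2 to compound 3 changed, but in the opposite direction: there, an aromatic ring giving way to methyl went with a number that was lower only to a degree the limit leaves open. Returning an aromatic ring is therefore expected to give, if anything, a higher number, with a fair chance that this assay again reports only a limit. Compound 4 is expected to come in at 150000 nM, between 40000 nM and 500000 nM, an expected step of a 2.0-fold higher number from compound 3 to compound 4 (0.31 log units; beyond the scatter).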

Compound 4, half-maximal inhibitory concentration: > 100000 nM
Compound 4: only a limit was reported; the forecaster's own chance of this, stated with the estimate: 55%; the middle value does not contradict the limit.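

In this assay, the new result tests a far larger ester on the oxygen that carries acetyl in compound 3, and pyridin-4-yl in place of methyl on the carbonyl carbon gives an at least 1.3-fold higher number from compound 3 to compound 4 (0.12 log units; that floor lies within the scatter). This oxygen now has three forms to compare: hydrogen in compound 1, acetyl in compound 3 and (pyridin-4-yl)carbonyl in compound 4, and only the acetyl form comes with a definite number, so neither removing the acetyl nor enlarging it to this ring-bearing group yields a measured potency. The step from compound 3 to compound 4 has no firm size and the step from compound 1 to compound 4 cannot be read at all, because the values rest on a ceiling of the test: the limit of > 100000 nM in this assay, at which 3 of the 4 values shown sit.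

The compounds shown leave open whether the ring nitrogen matters at all, since a plain phenyl on the same carbonyl carbon would separate the effect of the ring from that of the nitrogen. They also leave open whether a modestly longer chain on this carbonyl carbon, such as ethyl or propyl, would keep a definite number or lose it.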